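Moving the carboxamide on the azetidine of compound 1

This account rests on a few compounds, and the source may have more. Where it says the series, first, only, none or still open, it means among the compounds named here.

Compound 1 `NC(=O)C1CCN1Cc1ccc(OCc2cccc(F)c2)cc1`: 46 nM
Compound 2 `CC1(C)C[C@@H](C(N)=O)N(Cc2ccc(OCc3cccc(F)c3)cc2)C1`: 1420 nM
Compound 3 `C[C@H](NCc1ccc(OCc2cccc(F)c2)cc1Cl)C(N)=O`: 28 nM

In an assay on Sf9 cells for inhibition of Amine oxidase [flavin-containing] B (Homo sapiens), with stated times of 15 min and 60 min (on this read-out higher numbers stand for weaker inhibition and lower numbers for stronger inhibition), compound 1 gives 46 nM, the second highest of the three numbers. Its value and that of compound 3 lie within the usual scatter of each other, whereas the number of compound 2 stands well beyond it. Compound 4 `NC(=O)C1CN(Cc2ccc(OCc3cccc(F)c3)cc2)C1` differs from compound 1 by 3-carbamoylazetidin-1-yl in place of 2-carbamoylazetidin-1-yl on a saturated chain carbon bound to an aromatic carbon. For the measured compounds named here, no measured pair shows this change, so the direction rests on the shared pattern of compounds 1 and 3, both of which carry the carbamoyl on a carbon bound to the amine nitrogen. Compound 4 is therefore expected to be weaker, with a step of a 6.5-fold higher number from compound 1 to compound 4 (0.81 log units; beyond the scatter) beyond the scatter. The estimate for compound 4 is 300 nM, between 60 nM and 1500 nM.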

Compound 4, half-maximal inhibitory concentration: 1420 nM
The estimate for compound 4 lay 4.7-fold (0.68 log units) below the measured number; low and high end bracket the measured number.
By their numbers in this assay, from the lowest: compounds 3 and 1 (each within the scatter of the next); then compounds 2 and 4 (each within the scatter of the next).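

With the atoms unchanged and only their joining altered, 3-carbamoylazetidin-1-yl in place of 2-carbamoylazetidin-1-yl gives a 31-fold higher number from compound 1 to compound 4 (1.49 log units; beyond the scatter). For the compounds shown here, this is the first pair differing in one place, and it shows directly that inhibition depends strongly on where the carbamoyl group sits on this ring. Nothing measured here explains the size of this step.

The compounds shown leave open whether a carboxylic acid or an amine could stand in place of the carbamoyl group. They also leave open how a carbamoyl group on a longer chain would compare with compound 4.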